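Geranyl ether on the shared core: expectation for compound 4

The compounds below may be only part of what the source reports. "The series", "measured", "known", "first", "only" and "open" are said of these compounds alone.

Measured so far:
- compound 1 `CCCCCCCCCCO[C@H]1C=C(COC(C)=O)C(=O)[C@@H]2O[C@@](C)(OC)[C@](C)(OC)O[C@@H]12` — 33600 nM
- compound 2 `CO[C@]1(C)O[C@H]2[C@@H](OC/C=C/c3ccccc3)C=C(COC(C)=O)C(=O)[C@@H]2O[C@@]1(C)OC` — 44500 nM
- compound 3 `CO[C@]1(C)O[C@H]2[C@@H](O)C=C(COC(C)=O)C(=O)[C@@H]2O[C@@]1(C)OC` — "not determined" (no result reported)

Compound 3 carries a free hydroxy on the shared core and has no single number in an assay on isolated protein for inhibition of glutathione S-transferase Mu 1 (Homo sapiens), read by spectrophotometry, with a stated time of 3 min; on this read-out higher numbers stand for weaker inhibition and lower numbers for stronger inhibition; its place on the scale is therefore not fixed by its own result. Compound 4 `CO[C@]1(C)O[C@H]2[C@@H](OC/C=C(\C)CCC=C(C)C)C=C(COC(C)=O)C(=O)[C@@H]2O[C@@]1(C)OC` is obtained from it by the change (3,7-dimethylocta-2,6-dien-1-yl in place of hydrogen on an oxygen on a saturated carbon), that is, hydroxy to (3,7-dimethylocta-2,6-dien-1-yl)oxy. For the measured compounds named here, no step between compound 3 and compound 4 has been measured. Going by the values given here, the only measured step that bears on it is the exchange of one ether chain for another at the same oxygen, a 1.3-fold higher number from compound 1 to compound 2 (0.12 log units; within the scatter), which stays within the scatter. Both chain ethers in this assay sit in the same region, compound 1 at 33600 nM and compound 2 at 44500 nM. Compound 4 is another chain ether at that oxygen, so its number in this assay is expected to fall in the same region, with no direction beyond the scatter implied. The estimate for compound 4 is 38000 nM, expected to lie between 15000 nM and 95000 nM.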

Compound 4, half-maximal inhibitory concentration: 177000 nM
Estimate against measurement, compound 4: 4.7-fold (0.67 log units) below; the measured number lies above the stated range.
By their numbers in this assay, from the lowest: compounds 1 and 2 (each within the scatter of the next); then compound 4.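

The choice of ether chain at this oxygen matters in this assay: the 3,7-dimethylocta-2,6-dien-1-yl chain gives a 4.0-fold higher number from compound 2 to compound 4 (0.60 log units; beyond the scatter) and a 5.3-fold higher number from compound 1 to compound 4 (0.72 log units; beyond the scatter) whereas the exchange of nonyl for the cinnamyl-type chain gave only a 1.3-fold higher number from compound 1 to compound 2 (0.12 log units; within the scatter) in the earlier data. Among the three chain ethers, compound 4 is therefore the weakest inhibitor, so a chain on this oxygen does not by itself fix the number. Nothing at hand accounts for this separation.

Compound 3 gives no single number, so steps from the free hydroxy to the ethers cannot be read. Also open, as far as these compounds go, is whether a saturated 3,7-dimethyloctyl chain would track compound 4 or compound 1, and whether a shorter chain or one ending in an amine or a carboxylic acid would lower the number.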